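The compounds below may be only part of what the source reports. "The series", "measured", "known", "first", "only" and "open" are said of these compounds alone.

Of the compounds shown here, two have so far been measured in an assay on Ltk cells with metabotropic glutamate receptor 5 (Homo sapiens) as the target, read by fluorescence and calcium flux; a lower number here means a stronger inhibitor, a higher number a weaker inhibitor. Compound 1 `CCNc1cccnc1Nc1cccc(C)n1` gives 3000 nM in this assay. Compound 2 `CCOc1cc(-c2ccccc2C#N)cnc1Nc1cccc(C)n1` gives 37 nM in this assay, the lower of the two numbers, and the gap between it and compound 1 lies far beyond the usual scatter of repeated measurements, so compound 2 is clearly the stronger inhibitor of the pair.

Compound 3 `CCOc1cc(-c2cccnc2C#N)cnc1Nc1cccc(C)n1` has not yet been measured. It differs from compound 2 in one place: 2-cyanopyridin-3-yl in place of 2-cyanophenyl on an aromatic carbon. One ring carbon of the outer six-membered ring is thus swapped for a ring nitrogen, while the nitrile and everything else stay as they were.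

Among the compounds with values here, no pair of measured compounds isolates a change of this kind, so the expectation for compound 3 rests on compound 2 alone. Such a swap usually moves the number only modestly, and compound 3 is expected to show a small step, a 1.5-fold higher number from compound 2 to compound 3 (0.17 log units; within the scatter), that may well stay within the scatter. Compound 3 is therefore estimated at 55 nM in this assay, with a plausible range from 15 nM to 200 nM.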

Compound 3, half-maximal inhibitory concentration: 80 nM
The estimate for compound 3 lay 1.5-fold (0.16 log units) below the measured number; low and high end bracket the measured number.
By their numbers in this assay, from the lowest: compound 2; then compound 3; then compound 1.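

In this assay, replacing 2-cyanophenyl with 2-cyanopyridin-3-yl gives a 2.2-fold higher number from compound 2 to compound 3 (0.33 log units; beyond the scatter), so a change of a single ring atom in this group, with the nitrile kept, has a measurable effect on the number. The step is modest, and the group at this position, para to a (6-methylpyridin-2-yl)amino group, can carry a ring nitrogen without losing all activity, although here the swap gives a weaker inhibitor. The hydrogen-bond acceptor count of the group rises from 1 to 2 in this change, but a single pair cannot show whether that count has anything to do with the higher number, and no measurement at hand explains the step.

The compounds shown leave open whether a ring nitrogen placed elsewhere in the outer ring would give a similar step, or whether a second ring nitrogen, as in a pyrimidine, would raise the number further. They also leave open how the outer ring would respond if a fluorine atom, a methoxy group or a carboxylic acid took the place of the nitrile.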